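The source may report more compounds than this note shows. Statements on the series, on what has been measured and on what is new or still open speak of the compounds shown alone.

Measured in an ADME assay on HepG2 cells (Homo sapiens) for cytotoxicity, read by luminescence, CellTiter-Glo and ATP content, with a stated time of 72 h; on this read-out higher numbers stand for an effect only at larger amounts of compound and lower numbers for an effect already at smaller amounts:
compound 1 `COc1cccc(CNCCCNc2ccnc3cc(-c4ccc(C(F)(F)F)cc4)ccc23)c1O` gives 2210 nM
compound 2 `FC(F)(F)c1ccc(-c2ccc3c(NCCCNCc4ccco4)ccnc3c2)cc1` gives 3470 nM
compound 3 `COc1ccc(F)cc1CNCCCNc1ccnc2cc(-c3ccc(C(F)(F)F)cc3)ccc12` gives 5190 nM

Compound 1 stands lowest of the three numbers in this assay; its nearest neighbour is compound 2, with a 1.6-fold higher number from compound 1 to compound 2 (0.20 log units; within the scatter), and its furthest is compound 3, with a 2.3-fold higher number from compound 1 to compound 3 (0.37 log units; beyond the scatter). The remaining step, a 1.5-fold higher number from compound 2 to compound 3 (0.17 log units; within the scatter), is also small. All three measured steps vary the group on a saturated chain carbon bound to an amine nitrogen, and none of them goes beyond a modest size.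

Compound 4 `COc1cccc(CNCCCNc2ccnc3cc(CCc4ccccc4)ccc23)c1O` differs from compound 1 at another place: phenethyl in place of 4-(trifluoromethyl)phenyl on an aromatic carbon. Among the compounds with values here, no measured step touches this part of the core, so there is no direct precedent for it in this assay. The measured changes at the chain end moved the number only modestly, which gives some ground to expect that a change here also stays near the values seen. For compound 4 the estimate in this assay is 2500 nM, with a range from 1000 nM to 6500 nM. This corresponds to an expected step of a 1.1-fold higher number from compound 1 to compound 4 (0.05 log units; within the scatter), within the scatter. Within the data shown here, the range is kept wide; no measured compound carries this change.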

Compound 4, half-maximal effective concentration: 6800 nM
Compound 4: middle estimate off by 2.7-fold (0.43 log units), on the low side; measured number outside the range, above it.
By their numbers in this assay, from the lowest: compounds 1, 2, 3 and 4 (each within the scatter of the next, the first and the last beyond it).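

At this aromatic carbon of the shared core, phenethyl in place of 4-(trifluoromethyl)phenyl gives a 3.1-fold higher number from compound 1 to compound 4 (0.49 log units; beyond the scatter) in this assay and is the first step shown at this position. The position therefore affects this read-out: the number moves beyond the scatter even though one six-membered aromatic ring of carbon only is kept, and the step is modest in size, like a 2.3-fold higher number from compound 1 to compound 3 (0.37 log units; beyond the scatter) at the chain end. Nothing at hand accounts for the step.

The compounds shown do not separate the loss of the trifluoromethyl group from the arrival of the saturated link in phenethyl; an unsubstituted phenyl or a 4-methoxyphenyl at this carbon would address that. Also open, on these data alone, is whether the step carries over to other chain ends, such as furan-2-yl.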